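A Sulfonyl Cap on the Ring Nitrogen: Compound 4

This account rests on a few compounds, and the source may have more. Where it says the series, first, only, none or still open, it means among the compounds named here.

The shared core of this small set is shown by compound 1 `COc1ccc(-c2cc(=O)c3c(OC)cc(OC)cc3[nH]2)cc1`. In a functional assay on HepG2 cells (Homo sapiens) for antiproliferative activity, with a stated time of 72 h (a lower number here means that less compound is needed, a higher number that more compound is needed for the effect), compound 1 reaches only the limit of the measurement, > 31100 nM. Two sulfonylated relatives have been measured. Compound 2 `COc1ccc(-c2cc(=O)c3c(OC)cc(OC)cc3n2S(=O)(=O)c2ccc(C)c([N+](=O)[O-])c2)cc1` carries a 4-methyl-3-nitrophenyl group on the sulfonyl sulfur, and in this assay compound 2 also gives only a limit, > 51700 nM. Compound 3 `COc1ccc(-c2cc(=O)c3c(OC)cc(OC)cc3n2S(=O)(=O)c2ccc(Br)cc2)cc1` carries a 4-bromophenyl group there, and in this assay compound 3 gives 16300 nM. The step of an at least 1.9-fold lower number from compound 1 to compound 3 (0.28 log units; that floor lies within the scatter) and the step of an at least 3.1-fold lower number from compound 2 to compound 3 (0.50 log units; beyond the scatter) are the only ones that bear on the change at hand.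

Compound 4 `COc1ccc(-c2cc(=O)c3c(OC)cc(OC)cc3n2S(=O)(=O)c2ccc(C)cc2)cc1` differs from compound 1 in one place: (4-methylphenyl)sulfonyl in place of hydrogen on an aromatic nitrogen. The question is thus what a sulfonyl group bearing a plain 4-methylphenyl ring does, where the 4-bromophenyl of compound 3 brought a modest gain and the 4-methyl-3-nitrophenyl of compound 2 brought none that could be seen. Since the step of an at least 1.9-fold lower number from compound 1 to compound 3 (0.28 log units; that floor lies within the scatter) was modest at most, only a small change is expected for compound 4. For compound 4 the estimated step is an at least 1.2-fold lower number from compound 1 to compound 4 (0.09 log units; that floor lies within the scatter), which lies within the scatter. In this assay compound 4 is expected to give about 25000 nM, with a range from 10000 nM to 60000 nM.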

Compound 4, half-maximal effective concentration: > 44800 nM
Compound 4: only a limit was reported; the forecaster's own chance of this, stated with the estimate: 40%; middle value at least 1.7-fold (0.25 log units) from the limit.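

Going by these compounds alone, the step of an at least 2.7-fold higher number from compound 3 to compound 4 (0.43 log units; beyond the scatter) is the one readable result for compound 4 in this assay, and it comes from nothing more than methyl in place of bromo on an aromatic carbon. Within the data shown here, a sulfonyl group on the aromatic nitrogen therefore does not give a measured value on its own: of the three sulfonylated compounds, only compound 3, the one with the bromo group, gives a number rather than a limit. The steps linking compound 4 to compound 1 and to compound 2 cannot be read, and the reading for compound 4 is itself only a limit: the limit of > 44800 nM in this assay, at which 1 of the 4 values shown sits.

Among these compounds, with bromo as the only group here that gives a number, it remains open whether chloro or fluoro in its place, or an amine or a carboxylic acid on the same aromatic carbon, would also give one. How far the true values of compound 1, compound 2 and compound 4 lie past their limits also remains unknown, and with it any order among these three.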